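The source may report more compounds than this note shows. Statements on the series, on what has been measured and on what is new or still open speak of the compounds shown alone.

Compound 1 `COc1ncc(N2CCc3ncnc(O[C@H]4CCN(C(=O)C5CCOCC5)C4)c3C2)cc1C(F)(F)F` is one of two compounds of a shared core that have been measured in an ADME assay on isolated protein for inhibition of phosphatidylinositol 4,5-bisphosphate 3-kinase catalytic subunit beta isoform (Homo sapiens), read by Kinase-Glo, with a stated time of 60 min; a higher number here means a weaker inhibitor, a lower number a stronger inhibitor. In this assay compound 1 gives 1330 nM, the lowest of the two numbers. Its nearest neighbour is compound 2 `COc1ncc(N2CCc3ncnc(O[C@H]4CCN(C(=O)C5CCOCC5)C4)c3C2)cc1C`, which in this assay gives 4150 nM. For the measured compounds named here, the single measured step between them, a 3.1-fold higher number from compound 1 to compound 2 (0.49 log units; beyond the scatter), comes from a methyl in place of trifluoromethyl on an aromatic carbon.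

Compound 3 `CCC(=O)N1CC[C@H](Oc2ncnc3c2CN(c2cnc(OC)c(C(F)(F)F)c2)CC3)C1` differs from compound 1 elsewhere: ethyl in place of oxan-4-yl on a carbonyl carbon, on a carbonyl carbon whose other neighbours are an amide-type nitrogen in a ring. Going by the values given here, no measured step touches this carbonyl substituent, so the only measured step, from compound 1 to compound 2, concerns a different part of the molecule and does not bear directly on the change. With nothing to indicate a direction, compound 3 is expected to differ from compound 1 by a step of a 1.1-fold higher number from compound 1 to compound 3 (0.05 log units; within the scatter), within the scatter. Compound 3 is therefore estimated at 1500 nM in this assay, with a range from 600 nM to 4000 nM.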

Compound 3, half-maximal inhibitory concentration: 1710 nM
The estimate for compound 3 lay 1.1-fold (0.06 log units) below the measured number, within the range that was stated.
By their numbers in this assay, from the lowest: compounds 1 and 3 (each within the scatter of the next); then compound 2.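

Compounds 1 and 2 spoke only to a substituent on an aromatic carbon, whereas compound 3 adds a measured step on a carbonyl carbon whose other neighbours are an amide-type nitrogen in a ring. In this assay ethyl in place of oxan-4-yl gives a 1.3-fold higher number from compound 1 to compound 3 (0.11 log units; within the scatter), so the two compounds cannot be told apart even though a six-membered non-aromatic ring with its hydrogen-bond acceptor leaves and a group with no ring enters, unlike the methyl change on the aromatic carbon, which gives a 3.1-fold higher number from compound 1 to compound 2 (0.49 log units; beyond the scatter) and lies beyond the scatter. No measured information on the compounds offers an explanation for this result.

For the compounds shown here, how an amine, a carboxylic acid or a longer chain on this carbonyl carbon would read in this assay remains open, since oxan-4-yl and ethyl are the only two groups compared here and both carry no net charge. Also open, going by these compounds, is whether ethyl in place of oxan-4-yl would read the same way on the core of compound 2, which carries methyl in place of trifluoromethyl.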